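Working notes on the series: the step to compound 4

A few compounds are considered here, and "the series" means these few. Any claim that something is new, unique, unknown or untested is made for them only; others in the source may bear on it.

Compound 1 `O=C(O)C1=Cc2ccccc2OC1(OCc1cc(-c2ccc(F)cc2)no1)C(F)(F)F` gives 168000 nM in a functional assay on DU-145 cells (Homo sapiens) for inhibition, read by MTT assay, with a stated time of 24 h; on this read-out lower numbers stand for stronger inhibition and higher numbers for weaker inhibition.
Compound 2 `CCOC(=O)C1=Cc2ccccc2OC1(OCc1cn(CC(=O)Nc2cccc(F)c2)nn1)C(F)(F)F` gives > 150000 nM in this assay, which is a limit of the assay and not a number.
Compound 3 `CCOC(=O)C1=Cc2ccccc2OC1(OCc1cn(CC(=O)Nc2ccccc2Br)nn1)C(F)(F)F` gives > 150000 nM in this assay, again a limit of the assay and not a number.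

Compound 3 therefore stands at the limit of this assay, the place where two of the three values sit (the limit of > 150000 nM in this assay, at which 2 of the 3 values shown sit). Only compound 1 gives a number, and that number is weak. Compound 4 `CCOC(=O)C1=Cc2ccccc2OC1(OCc1cn(-c2ccccc2)nn1)C(F)(F)F` differs from compound 3 in one place: phenyl in place of ((2-bromophenyl)carbamoyl)methyl on an aromatic nitrogen. Within the data shown here, the single measured step, a step that the two limits leave unreadable from compound 2 to compound 3, runs from one limit to another and is unreadable in size. Among the measured compounds shown here, no measured step replaces ((2-bromophenyl)carbamoyl)methyl with phenyl on an aromatic nitrogen, so nothing measured sizes this change. Compound 4 is thus expected to remain weak, and the expected step that the limit leaves unreadable from compound 3 to compound 4 is not readable against the limit of compound 3. The estimate for compound 4 is 160000 nM, with a range from 60000 nM to 450000 nM.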

Compound 4, half-maximal inhibitory concentration: > 150000 nM
Compound 4 ended at the assay's limit; the forecaster's own chance of this, stated with the estimate: 65%; the middle value lies beyond the limit too.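

In this assay, among these compounds, compound 4 gives > 150000 nM, a limit of the assay and not a number, so no step from compound 2 or compound 3 to compound 4 can be read. The compounds shown leave open whether any group on the aromatic nitrogen of this ester series gives a measurable value: the limit of > 150000 nM in this assay, at which 3 of the 4 values shown sit.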